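The source may report more compounds than this note shows. Statements on the series, on what has been measured and on what is new or still open speak of the compounds shown alone.

Measured so far:
- Compound 1, `CCOC(=O)C(=O)Nc1ccccc(C)c1=O`: 40%
- Compound 2, `CCOC(=O)C(=O)Nc1ccccc(OC)c1=O`: 24%

In a functional assay on the whole organism (strain Sprague-Dawley CD) for inhibition, with Rattus norvegicus as the target, read by paw edema, at a dose of 10 mg/kg by the intraperitoneal route (a higher number here means a stronger effect of the compound at the dose given, a lower number a weaker effect), compound 1 gives 40%, and compound 2 gives 24%. Compound 2 stands lowest of the two numbers, and its nearest neighbour is compound 1, reached by the step of a number 16 percentage points lower from compound 1 to compound 2 (beyond the scatter). Compound 3, `CCOC(=O)C(=O)Nc1ccccc(NC)c1=O`, is not yet measured in this assay. It differs from compound 2 as follows: methylamino in place of methoxy on an aromatic carbon. Within the data shown here, the only measured step that bears on this change is the one from methyl to methoxy, a number 16 percentage points lower from compound 1 to compound 2 (beyond the scatter), which was modest. It exchanges one group on the same aromatic carbon, but neither it nor any other measured step shows what a methylamino group does at that position, so the direction for compound 3 cannot be taken from the data. The step to compound 3 is therefore expected to be small, a number 3 percentage points higher from compound 2 to compound 3 (within the scatter), with a wide range. Compound 3 is estimated at 27%, between 10% and 45%.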

Compound 3, a percentage reported as inhibition, in the whole organism at one dose (the size of the read-out at that dose, not a potency): 73%
Estimate against measurement, compound 3: 46 percentage points below; measured number above the stated range.
By their numbers in this assay, from the lowest: compound 2; then compound 1; then compound 3.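

In this assay, this aromatic carbon responds strongly to the group it carries, and exchanging methoxy for methylamino gives a number 49 percentage points higher from compound 2 to compound 3 (beyond the scatter), a rise where the change from methyl to methoxy had brought a fall. Methylamino also outperforms methyl at the same place, with a number 33 percentage points higher from compound 1 to compound 3 (beyond the scatter), so compound 3 stands highest of the three, with its steps to both others beyond the scatter. The change from methoxy brings in a hydrogen-bond donor, but nothing available here explains the rise.

From the compounds shown here alone, whether the rise depends on the hydrogen of the methylamino group stays open, and a dimethylamino group or an unsubstituted amine on the same carbon would bear on that. Going by these compounds, how far the group can grow also remains open, for instance with ethylamino or a longer chain.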